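This account rests on a few compounds, and the source may have more. Where it says the series, first, only, none or still open, it means among the compounds named here.

Of the compounds shown here, two have so far been tested in a functional assay on the whole organism for inhibition, with Rattus norvegicus as the target, read by paw edema, with a stated time of 4 h, at a dose of 50 mg/kg; on this read-out lower numbers stand for less inhibition and higher numbers for more inhibition at the one dose given (going by the name of the read-out). Compound 1 `CC(=O)c1c(NNc2cc(C)c3ccccc3n2)cc(C)oc1=O` gives 51%. Compound 2 `Cc1cc2nn(-c3ccccc3)c(C)c2c(=O)o1` gives 43.1% in this assay, and the two numbers lie within the usual scatter of each other, so on this read-out the two stand level and neither can be set above the other. The next compound, compound 3 `Cc1cc2nn(-c3ccc(Br)cc3)c(C)c2c(=O)o1`, differs from compound 2 in one place: bromo in place of hydrogen on an aromatic carbon. No measured pair among these compounds shows what such a change does, so there is no known step to lean on. With nothing to point in either direction, the estimated step in this assay is a number 1.9 percentage points higher from compound 2 to compound 3 (within the scatter), that is, no step beyond the scatter. Compound 3 is therefore estimated to give 45% in this assay, with a range from 25% to 65%.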

Compound 3, a percentage reported as inhibition, in the whole organism at one dose (the size of the read-out at that dose, not a potency): 38.2%
For compound 3 the middle estimate is 6.8 percentage points above the measured one; measured number inside the range.
By their numbers in this assay, from the lowest: compounds 3, 2 and 1 (each within the scatter of the next, the first and the last beyond it).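

Bromo in place of hydrogen on an aromatic carbon, para to a large group, gives a number 4.9 percentage points lower from compound 2 to compound 3 (within the scatter) in this assay. Among these compounds, this is the first measured case of this change, and it shows that at this place on the six-membered aromatic ring a bromine atom can take the place of hydrogen with no step beyond the scatter, so compound 2 and compound 3 stand level. Nothing measured here speaks to what lies behind this result.

The compounds shown leave open whether a different group at this same place, such as an amine, a methoxy group or a carboxylic acid, would give a step beyond the scatter from compound 2. They also leave open whether bromo at another place on this ring would leave the read-out level as well.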